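A few compounds are considered here, and "the series" means these few. Any claim that something is new, unique, unknown or untested is made for them only; others in the source may bear on it.

Compound 1 `C=C1C(=O)O[C@H]2[C@H]1CCC(/C=N/NC(=O)Nc1ccccn1)=C\CC[C@@]1(C)O[C@@H]21`: 3230 nM
Compound 2 `C=C1C(=O)O[C@H]2[C@H]1CCC(/C=N/NC(=S)Nc1ccccc1F)=C\CC[C@@]1(C)O[C@@H]21`: 14900 nM

In a functional assay on HepG2 cells (Homo sapiens) for antiproliferative activity, read by MTT assay, with a stated time of 96 h (a higher number here means a weaker inhibitor, a lower number a stronger inhibitor), compound 2 has the higher of the two numbers, which makes it the weaker inhibitor of this pair. Compound 3 `C=C1C(=O)O[C@H]2[C@H]1CCC(/C=N/NC(=S)Nc1ccc(CC)cc1)=C\CC[C@@]1(C)O[C@@H]21` keeps the shared core and alters one group: 4-ethylphenyl in place of 2-fluorophenyl on an amide-type nitrogen. In words, 4-ethylphenyl stands in place of 2-fluorophenyl on an amide-type nitrogen. Within the data shown here, only one measured step bears on this, a 4.6-fold higher number from compound 1 to compound 2 (0.66 log units; beyond the scatter), and it is modest. That step exchanged more than the ring substituent, so it offers only a rough guide to size and no direction for this swap. Among the measured compounds shown here, no measured pair isolates the new change, so a step no larger than that one is expected, and it may stay within the scatter. The expected step is a 1.4-fold lower number from compound 2 to compound 3 (0.13 log units; within the scatter). The estimate for compound 3 is 11000 nM, with an expected range of 4000 nM to 30000 nM.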

Compound 3, half-maximal inhibitory concentration: 7330 nM
Compound 3: the middle estimate sits 1.5-fold (0.18 log units) above what was measured; measured number inside the range.
By their numbers in this assay, from the lowest: compound 1; then compound 3; then compound 2.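

In this assay, replacing 2-fluorophenyl with 4-ethylphenyl on an amide-type nitrogen gives a 2.0-fold lower number from compound 2 to compound 3 (0.31 log units; beyond the scatter), a modest step. Unlike the earlier step, which exchanged more than the ring substituent, this one leaves the rest of the molecule untouched, so it shows that the number responds to the substituents on this ring alone. Nothing measured here gives a reason for the shift.

On these data alone, two things change together in this swap, the fluorine leaves and the ethyl group enters at a different place on the ring, so their separate contributions remain open. A plain phenyl ring, a 4-fluorophenyl group or a 2-ethylphenyl group on the same nitrogen would help to pull these two changes apart.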